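Oral Exposure Expected After Swapping Acetamido for Dimethylcarbamoyl

The compounds below may be only part of what the source reports. "The series", "measured", "known", "first", "only" and "open" are said of these compounds alone.

Compound 1 `CCCCN(c1nc2c(-c3nccn3C)cccc2o1)[C@H](C)c1ccc(-c2ccccc2-c2nnn[nH]2)cc1`: 152 ng.h/mL
Compound 2 `CCCCN(c1nc2c(NC(C)=O)cccc2o1)[C@H](C)c1ccc(-c2ccccc2-c2nnn[nH]2)cc1`: 41.6 ng.h/mL

In an ADME assay on the whole organism (Macaca fascicularis) for pharmacokinetics, read by LC-MS, using cassette dosing, at a dose of 1 mg/kg by the oral route (on this read-out lower numbers stand for lower exposure and higher numbers for higher exposure at the dose given), compound 1 gives 152 ng.h/mL and compound 2 gives 41.6 ng.h/mL. Going by the values given here, compound 2 thus holds the lower of the two measured numbers, and the single measured step, a 3.7-fold lower number from compound 1 to compound 2 (0.56 log units; beyond the scatter), is modest. Compound 3 `CCCCN(c1nc2c(C(=O)N(C)C)cccc2o1)[C@H](C)c1ccc(-c2ccccc2-c2nnn[nH]2)cc1` differs from compound 2 by dimethylcarbamoyl in place of acetamido on an aromatic carbon. Among the compounds with values here, no measured step covers this exchange directly, so the expectation rests only on the size of that one step at the same position. For compound 3 the expected change is a 1.4-fold higher number from compound 2 to compound 3 (0.16 log units; within the scatter). Compound 3 is estimated at 60 ng.h/mL, in a range from 20 ng.h/mL to 180 ng.h/mL.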

Compound 3, area under the concentration-time curve: 104 ng.h/mL
The estimate for compound 3 lay 1.7-fold (0.24 log units) below the measured number; low and high end bracket the measured number.
By their numbers in this assay, from the lowest: compound 2; then compounds 3 and 1 (each within the scatter of the next).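

In this assay, dimethylcarbamoyl in place of acetamido on this aromatic carbon gives a 2.5-fold higher number from compound 2 to compound 3 (0.40 log units; beyond the scatter), so the read-out also responds to an exchange between two groups without a ring. Dimethylcarbamoyl in place of 1-methyl-1H-imidazol-2-yl gives a 1.5-fold lower number from compound 1 to compound 3 (0.16 log units; within the scatter), so at this position a group without a ring can stand level with the ring-bearing one. Nothing available on these compounds accounts for either step. As far as these compounds go, what a carboxylic acid or a primary amine on this carbon would give remains open, as does whether these steps hold with a chain other than butyl on the shared core.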